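Dropping a trifluoromethyl group: what to expect

A few compounds are considered here, and "the series" means these few. Any claim that something is new, unique, unknown or untested is made for them only; others in the source may bear on it.

Measured so far:
Compound 1 `O=C(Nc1cccc(-n2cc(-c3ccncc3)c(-c3ccc(Cl)c(O)c3)n2)c1)Nc1cccc(C(F)(F)F)c1` gives 1860 nM
Compound 2 `COc1cc(-c2nn(-c3cccc(NC(=O)c4cccc(C(F)(F)F)c4)c3)cc2-c2ccncc2)ccc1Cl` gives 968 nM
Compound 3 `O=C(Nc1cccc(-n2cc(-c3ccncc3)c(-c3ccc(Cl)c(O)c3)n2)c1)Nc1cc(C(F)(F)F)cc(C(F)(F)F)c1` gives 647 nM

These three compounds were tested in a functional assay on UO-31 cells (Homo sapiens) for inhibition, read by sulforhodamine B assay, with a stated time of 48 h; a higher number here means a weaker inhibitor of growth, a lower number a stronger inhibitor of growth. Compound 2 holds the second-highest of the three numbers; compound 3 is its nearest neighbour, and compound 1 sits on the other side, but both gaps lie within the usual scatter, so no order among the three can be claimed.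

Compound 4 `COc1cc(-c2nn(-c3cccc(NC(=O)c4ccccc4)c3)cc2-c2ccncc2)ccc1Cl` is the partner of compound 2 in this step. The change is hydrogen in place of trifluoromethyl on an aromatic carbon. Within the data shown here, only one measured step bears on it: a 2.9-fold lower number from compound 1 to compound 3 (0.46 log units; beyond the scatter), where a trifluoromethyl entered and the number fell. That step runs in the opposite direction to the present one, on a related but not identical side chain, since compound 1 and compound 3 carry a urea while compound 2 carries an amide. Taken as the nearest guide, the step that is expected here is a 2.3-fold higher number from compound 2 to compound 4 (0.36 log units; beyond the scatter), and this is an estimate rather than a measurement: removing the trifluoromethyl would raise the number modestly, likely beyond the scatter but not by much. Compound 4 is therefore estimated at 2200 nM, with a plausible range from 800 nM to 6000 nM.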

Compound 4, concentration for 50% growth inhibition: 638 nM
Compound 4: the middle estimate sits 3.4-fold (0.54 log units) above what was measured, and the stated range ends above it.
By their numbers in this assay, from the lowest: compounds 4, 3, 2 and 1 (each within the scatter of the next, the first and the last beyond it).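

On the amide side chain, replacing the trifluoromethyl with hydrogen gives a 1.5-fold lower number from compound 2 to compound 4 (0.18 log units; within the scatter). In this assay, this pair therefore shows no measurable effect of having a trifluoromethyl at this position on the benzoyl ring. The earlier step came from a urea pair, where a second trifluoromethyl joined a ring that already carried one, and its result does not carry over to this amide pair, where the only trifluoromethyl leaves: the same change on two cores in this assay, a 2.9-fold lower number (0.46 log units; beyond the scatter) from compound 1 to compound 3 and a 1.5-fold higher number (0.18 log units; within the scatter) from compound 4 to compound 2, 4.4-fold (0.64 log units) apart, beyond the scatter of two such steps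

The two pairs differ in more than one place, with a urea and a hydroxyl group in compound 1 and compound 3 but an amide and a methoxy group in compound 2 and compound 4, and the compounds shown cannot tell which of these differences, or the number of trifluoromethyl groups on the ring, separates the two steps. As far as these compounds go, how this position responds to other groups also remains open, for example an amine, a carboxylic acid or a longer chain in place of the hydrogen of compound 4.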